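The compounds below may be only part of what the source reports. "The series", "measured", "known", "first", "only" and "open" are said of these compounds alone.

In a functional assay on the whole organism with Mus musculus as the target, in the writhing test (on this read-out lower numbers stand for an effect already at smaller amounts and higher numbers for an effect only at larger amounts of compound), three compounds have been measured so far:

Compound 1 `CCn1nc(C)c2c(C)cc(=O)oc21` gives 24.9 mg/kg.
Compound 2 `Cc1cc(=O)oc2c1c(C)nn2CCO` gives 100 mg/kg.
Compound 3 `Cc1cc(=O)oc2c1c(C)nn2C(C)C` gives > 100 mg/kg, which is a limit of the assay and not a number.

Compound 3 therefore stands at the weak end of the three, and only a limit is known for it, namely (the limit of > 100 mg/kg in this assay, at which 1 of the 3 values shown sits).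

The unmeasured compound 4 `Cc1cc(=O)oc2c1c(C)nn2C` differs from compound 3 in one place: methyl in place of isopropyl on an aromatic nitrogen. Two of the measured steps bear on this change. The step from compound 1 to compound 3 added a methyl on the chain carbon bound to the aromatic nitrogen and gave an at least 4.0-fold higher number from compound 1 to compound 3 (0.60 log units; beyond the scatter). The step from compound 2 to compound 3 gave a number no lower from compound 2 to compound 3 (the limit leaves the size open). Going from isopropyl to methyl removes that added carbon and one more, so the number for compound 4 is expected to fall back, giving an at least 3.3-fold lower number from compound 3 to compound 4 (0.52 log units; beyond the scatter). Within the data shown here, no measured step covers a chain shorter than ethyl, so the value of compound 1 is the best guide. Compound 4 is therefore estimated at 30 mg/kg, within a range from 10 mg/kg to 100 mg/kg.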

Compound 4, dose for half-maximal effect: 11.6 mg/kg
Beside the measured number, compound 4's estimate is 2.6-fold (0.41 log units) above it, and the stated range covers the measured number.
By their numbers in this assay, from the lowest: compound 4; then compound 1; then compound 2.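

Compound 4 shows that the shortest group so far on this aromatic nitrogen gives the lowest number in this assay, and its steps to all three other compounds lie beyond the scatter. Among the plain carbon groups, the number rises as the group grows from methyl through ethyl to isopropyl, with a 2.1-fold lower number from compound 1 to compound 4 (0.33 log units; beyond the scatter) and an at least 8.6-fold lower number from compound 3 to compound 4 (0.93 log units; beyond the scatter), while the hydroxy-bearing chain of compound 2, which lies outside this series, gives an 8.6-fold lower number from compound 2 to compound 4 (0.94 log units; beyond the scatter). The size of the isopropyl step stays open-ended, since the value of compound 3 is a limit and not a number: the limit of > 100 mg/kg in this assay, at which 1 of the 4 values shown sits.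

The compounds shown do not tell whether the number would fall further with hydrogen on this nitrogen, or how a group of another kind, such as a chain ending in an amine or a carboxylic acid, would compare with methyl. They also leave open why methyl gives the lowest number, and whether the rise from methyl to isopropyl would hold for a longer chain or a cyclopropyl group.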